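A few compounds are considered here, and "the series" means these few. Any claim that something is new, unique, unknown or untested is made for them only; others in the source may bear on it.

Measured so far, in an assay on HEK293 cells for displacement of a labelled ligand from transient receptor potential cation channel subfamily V member 1 (Homo sapiens); a higher number here means a weaker inhibitor, a lower number a stronger inhibitor:

compound 1 `CC(C)c1ccccc1N1CCC(C(=O)Nc2ccc3c(c2)NC(=O)CO3)CC1` — 78 nM
compound 2 `O=C1COc2ccc(NC(=O)C3CCN(c4cccc(Cl)c4)CC3)cc2N1` — 97 nM

Both compounds share the same core and differ only in the group on the amine nitrogen of the six-membered non-aromatic ring. For the measured compounds named here, compound 2 gives the higher of the two numbers, but its only neighbour is compound 1, and the step of a 1.2-fold higher number from compound 1 to compound 2 (0.09 log units; within the scatter) is within the scatter, so the two cannot be told apart.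

Compound 3 `O=C1COc2ccc(NC(=O)C3CCN(c4cc(F)c(F)c(F)c4)CC3)cc2N1` is not yet measured. It differs from compound 2 as follows: 3,4,5-trifluorophenyl in place of 3-chlorophenyl on an amine nitrogen in a ring. Going by the values given here, the one measured step that bears on this is the swap of the group on that same nitrogen, from compound 1 to compound 2, which was a 1.2-fold higher number from compound 1 to compound 2 (0.09 log units; within the scatter) and changed nothing beyond the scatter. A further swap of the aromatic group at this position is therefore expected to leave this assay broadly where it stands, with no step beyond the scatter.

Compound 3 is thus expected to give about 110 nM, between 45 nM and 300 nM, meaning an expected step of a 1.1-fold higher number from compound 2 to compound 3 (0.05 log units; within the scatter).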

Compound 3, inhibition constant: 49 nM
Beside the measured number, compound 3's estimate is 2.2-fold (0.35 log units) above it; measured number inside the range.
By their numbers in this assay, from the lowest: compounds 3, 1 and 2 (each within the scatter of the next).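

In this assay the swap to 3,4,5-trifluorophenyl gives two steps, and both stay within the scatter: one is a 2.0-fold lower number from compound 2 to compound 3 (0.30 log units; within the scatter) and the other is a 1.6-fold lower number from compound 1 to compound 3 (0.20 log units; within the scatter). The earlier pair showed only that 2-isopropylphenyl and 3-chlorophenyl on the amine nitrogen could not be told apart, whereas these three compounds now show the same for a third aromatic group, one that carries three fluorine atoms and brings 9 heavy atoms in place of the 7 of 3-chlorophenyl. Nothing available explains why these three groups cannot be told apart in this measurement.

As far as these compounds go, all three compounds keep a six-membered aromatic ring of carbon only on that nitrogen, so it remains open whether a pyridine ring, a saturated cyclohexyl group or a phenyl ring bearing an amine or a carboxylic acid would keep the number in this range. The shared core and its amide also stay the same throughout, so these compounds say nothing about how much a change in either would matter.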